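The source may report more compounds than this note shows. Statements on the series, on what has been measured and on what is new or still open speak of the compounds shown alone.

In a physicochemical assay, with a stated time of 6 min (a higher number here means a weaker inhibitor, a lower number a stronger inhibitor), compound 1 (`Cc1ccc(NC(=O)Nc2nc(-c3cc4cc(Br)ccc4o3)cs2)cc1`) gives > 200000 nM, which is a limit of the assay and not a number. Compound 3 (`Cc1ccc(NC(=O)Nc2nc(-c3cc4ccccc4o3)cs2)cc1`) differs from compound 1 in a single place, with hydrogen in place of bromo on an aromatic carbon. Within the data shown here, the only measured comparison involves compound 2 (`O=C(Nc1nc(-c2cc3cc(Br)ccc3o2)cs1)Nc1ccccc1[N+](=O)[O-]`), which gives 166000 nM. That comparison is an at least 1.2-fold lower number from compound 1 to compound 2 (0.08 log units; that floor lies within the scatter). Among the measured compounds shown here, it changes a different part of the molecule and leaves the bromo untouched, so no measured step speaks directly to this change. With so little to go on, no clear direction can be expected, and compound 3 is expected to stay very weak, close to the limit reached by compound 1. The expected change is an at least 1.1-fold lower number from compound 1 to compound 3 (0.04 log units; that floor lies within the scatter). For compound 3 the estimated value is 180000 nM, with an expected range from 60000 nM to 400000 nM.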

Compound 3, half-maximal inhibitory concentration: 500 nM
Beside the measured number, compound 3's estimate is 360-fold (2.56 log units) above it; measured number below the stated range.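

In this assay, the step from bromo to hydrogen on this aromatic carbon is an at least 400-fold lower number from compound 1 to compound 3 (2.60 log units; beyond the scatter), so losing this one heavy atom goes with a much stronger inhibitor. Among these compounds, the earlier step changed another part of the molecule and its floor stayed within the scatter, so this is the first sign that a single position on the core can move the number this far. The size of this step is only a floor, since one end of the comparison is a limit of the assay and not a number: the limit of > 200000 nM in this assay, at which 1 of the 3 values shown sits.

Only bromo and hydrogen appear at this position among the compounds shown, so it remains open how a fluoro, a chloro, a methyl or a methoxy group there would compare. Going by these compounds, it also remains open whether the same change would have a similar effect with the 2-nitrophenyl group of compound 2 in place of the 4-methylphenyl group.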